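Aryl-halogen variation on the biaryl ether pyridone series

A few compounds are considered here, and "the series" means these few. Any claim that something is new, unique, unknown or untested is made for them only; others in the source may bear on it.

Measured so far in a functional assay on CHO cells for positive allosteric modulation of metabotropic glutamate receptor 2 (Homo sapiens), read by scintillation counting and GTPgammaS binding, with a stated time of 30 min; on this read-out higher numbers stand for an effect only at larger amounts of compound and lower numbers for an effect already at smaller amounts:
Compound 1 `CC(C)CCn1ccc(-c2ccc(OCC3CC3)cc2)c(C#N)c1=O`: 290 nM
Compound 2 `CCCCn1ccc(-c2ccc(Oc3ccnc(C)c3)cc2)c(C#N)c1=O`: 398 nM
Compound 3 `CCCCn1ccc(-c2ccc(Oc3ccnc(C)c3)cc2Cl)c(C#N)c1=O`: 933 nM

Compound 3 stands with the highest number of the three in this assay. Its nearest neighbour is compound 2, which differs only by hydrogen at the carbon that carries chloro in compound 3; the gap is a 2.3-fold higher number from compound 2 to compound 3 (0.37 log units; beyond the scatter). Compound 1, with a different chain and a different ether group, lies furthest from compound 3 in this assay.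

Compound 4 `CCCCn1ccc(-c2ccc(Oc3ccnc(C)c3)cc2F)c(C#N)c1=O` is not yet measured. It is derived from compound 3 by fluoro in place of chloro on an aromatic carbon. Going by the values given here, the only measured step that bears on this position is the one from compound 2 to compound 3, hydrogen to chloro, which raised the number modestly, beyond the scatter. Compound 4 places a third substituent, fluoro, at the same aromatic carbon. Among the compounds with values here, with no fluoro analogue measured anywhere, the expectation rests on that single step: the number for compound 4 is expected to fall between those of compound 2 and compound 3, giving an estimated step of a 1.6-fold lower number from compound 3 to compound 4 (0.19 log units; within the scatter) in this assay. The estimate for compound 4 in this assay is 600 nM, with a range from 300 nM to 1200 nM; a step that stays within the scatter of compound 3 cannot be excluded.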

Compound 4, half-maximal effective concentration: 390 nM
The estimate for compound 4 lay 1.5-fold (0.19 log units) above the measured number, and the stated range covers the measured number.
By their numbers in this assay, from the lowest: compounds 1, 4 and 2 (each within the scatter of the next); then compound 3.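

On the aromatic carbon ortho to a large group, the two halogens do not behave alike in this assay: fluoro in place of chloro gives a 2.4-fold lower number from compound 3 to compound 4 (0.38 log units; beyond the scatter) and so separates the halogens by a step beyond the scatter, which the hydrogen-to-chloro step alone could not show. Fluoro in place of hydrogen gives a 1.0-fold lower number from compound 2 to compound 4 (0.01 log units; within the scatter), so this carbon accepts fluoro without a readable shift, and among hydrogen, fluoro and chloro here, only chloro stands apart from the other two. Nothing available explains why chloro and fluoro part at this carbon.

From the compounds shown here alone, whether bromo, methyl or methoxy at the same carbon would read like chloro or like fluoro remains open, so three substituents at one position give no trend yet. Also open, going by these compounds, is whether the same halogen steps would appear with the chain and cyclopropylmethoxy group of compound 1, or with a longer chain than butyl on the shared core, since all three halogen comparisons rest on a single background.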